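Longer Alkyl Chain on the Oxygen: Compound 3 to Compound 4

This account rests on a few compounds, and the source may have more. Where it says the series, first, only, none or still open, it means among the compounds named here.

Compound 3 `CCCCCCOC(=O)CC(=O)Nc1c(C(C)C)cccc1C(C)C` gives 810 nM in an assay on microsomes from intestine for inhibition of acyl-CoA:cholesterol acyltransferase (Oryctolagus cuniculus) (on this read-out higher numbers stand for weaker inhibition and lower numbers for stronger inhibition), the highest number among the three measured compounds. Compound 1 `CCCCCCCCCCOC(=O)CC(=O)Nc1c(C(C)C)cccc1C(C)C` gives 53 nM, and compound 2 `CCCCC(C)(C)OC(=O)CC(=O)Nc1c(C(C)C)cccc1C(C)C` gives 15 nM. Compound 4 `CCCCCCCCCCCCCCCCOC(=O)CC(=O)Nc1c(C(C)C)cccc1C(C)C` differs from compound 3 by decyl in place of hydrogen on a saturated chain carbon, six bonds along the chain from an oxygen next to a carbonyl group. For the measured compounds named here, two measured steps bear on this change. In the step of a 15-fold higher number from compound 1 to compound 3 (1.18 log units; beyond the scatter), a shorter chain on the oxygen went with the higher number, and the step of a 54-fold higher number from compound 2 to compound 3 (1.73 log units; beyond the scatter) points the same way. Adding decyl to compound 3 runs opposite to the first of these, so a lower number is expected for compound 4, although no measured compound tells whether a chain this long keeps the whole gain. Compound 4 is therefore estimated at 45 nM, within 10 nM to 250 nM, a step of an 18-fold lower number from compound 3 to compound 4 (1.26 log units; beyond the scatter).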

Compound 4, half-maximal inhibitory concentration: 35 nM
Estimate against measurement, compound 4: 1.3-fold (0.11 log units) above; the range from low to high includes it.
By their numbers in this assay, from the lowest: compound 2; then compounds 4 and 1 (each within the scatter of the next); then compound 3.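

In this assay adding decyl to the saturated chain carbon gives a 23-fold lower number from compound 3 to compound 4 (1.36 log units; beyond the scatter), so a chain this long keeps the gain seen with the earlier longer and branched groups. The last stretch of that chain, hexyl, gives a 1.5-fold lower number from compound 1 to compound 4 (0.18 log units; within the scatter), which means this added length brings no change that can be read. No measurement here explains why the chain length matters.

On these data alone, it stays open whether a still longer chain would hold this level, and whether an amine or a carboxylic acid at the chain end would be tolerated.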